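The compounds below may be only part of what the source reports. "The series", "measured", "known", "first", "only" and "open" are said of these compounds alone.

Measured so far:
- compound 1, `O=C(NO)c1cccc(-c2cn([C@H]3C[C@@H](CO)N(Cc4ccccc4)C3)nn2)c1`: < 10%
- compound 2, `O=C(NO)c1cccc(-c2cn([C@@H]3C[C@H](C(=O)O)N(Cc4ccccc4)C3)nn2)c1`: < 10%

In an assay on Sf9 cells for inhibition of histone deacetylase 11 (Homo sapiens), read by fluorescence, tested at 0.5 uM (on this read-out lower numbers stand for less inhibition and higher numbers for more inhibition at the one concentration tested (going by the name of the read-out)), compound 2 gives < 10%, which is a limit of the assay and not a number. Compound 1 in this assay likewise gives < 10%, again a limit rather than a measured figure. Going by the values given here, both measured compounds therefore stand at the same limit, as the limit of < 10% in this assay, at which 2 of the 2 values shown sit, records, and no step between measured compounds can be taken from them; where compound 2 stands is known only as that limit. Compound 3, `O=C(NO)c1cccc(-c2cn([C@@H]3C[C@H](CO)N(Cc4ccccc4)C3)nn2)c1`, differs from compound 2 by hydroxymethyl in place of carboxy on a saturated ring carbon. With both measured compounds at the limit, compound 3 is expected to show no step beyond the scatter in this assay, a change of a step that the limit leaves unreadable from compound 2 to compound 3. Compound 3 is estimated at 5%, with a range from 0% to 15%, and most probably is reported once more only as a limit.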

Compound 3, a percentage reported as inhibition, at one concentration (the size of the read-out at that concentration, not a potency): < 10%
Compound 3: no number, only a limit; the forecaster's own chance of this, stated with the estimate: 80%; the middle value lies beyond the limit too.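

In this assay, no step can be read from compound 2 to compound 3 or from compound 1 to compound 3, as all three compounds stand at one limit: the limit of < 10% in this assay, at which 3 of the 3 values shown sit.

The compounds shown leave open whether hydroxymethyl in place of carboxy, or the configuration as drawn, changes the inhibition in this assay at all.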